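Shortening the Propylamino Chain on a Nitrile Quinoline Core

The source may report more compounds than this note shows. Statements on the series, on what has been measured and on what is new or still open speak of the compounds shown alone.

In a functional assay on SW480 cells (Homo sapiens) for inhibition, read by luminescence and resazurin assay, with a stated time of 3 days (on this read-out lower numbers stand for stronger inhibition and higher numbers for weaker inhibition), compound 1, whose structure is `CCCNc1nc2ccccc2c(NCc2ccc(NC(=O)c3ccc(F)cc3)cc2)c1C#N`, gives only a limit of > 20000 nM, not a number. Compound 2, with the structure `CCNc1ncc(C)c(NCc2ccc(NC(=O)c3ccc(F)cc3)cc2)n1`, also reaches only a limit of > 20000 nM in this assay. Compound 1 therefore stands at the limit of > 20000 nM in this assay, at which 2 of the 2 values shown sit, so no numerical position can be assigned to it among the values shown. Compound 3, with the structure `CNc1nc2ccccc2c(NCc2ccc(NC(=O)c3ccc(F)cc3)cc2)c1C#N`, has not been measured; it differs from compound 1 by hydrogen in place of ethyl on a saturated chain carbon bound to a nitrogen on an aromatic ring, which cut one bond further out reads propyl to methyl. Among the measured compounds shown here, since no step between measured compounds exists here, the expected change in this assay rests only on the fact that compound 1 sits at a limit of > 20000 nM. Compound 3 is therefore expected to remain at or near that limit, with an estimated value of 30000 nM in a range from 10000 nM to 100000 nM, an expected step that the limit leaves unreadable from compound 1 to compound 3 that stays within the scatter.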

Compound 3, half-maximal inhibitory concentration: > 20000 nM
Compound 3: a limit, no number (the forecaster's own chance of this, stated with the estimate: 85%); the middle value is on the limit's open side.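

Compound 1 and compound 3 each give only a limit, not a number, so no step can be read from compound 1 to compound 3: the limit of > 20000 nM in this assay, at which 3 of the 3 values shown sit.

The compounds shown leave open whether propylamino and methylamino differ at all on this core in this assay.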